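From a Methylpyrrole to an Aminophenyl on the Shared Core

A few compounds are considered here, and "the series" means these few. Any claim that something is new, unique, unknown or untested is made for them only; others in the source may bear on it.

Compound 1 `Cn1cccc1C(=O)/C=C/c1ccc2c(c1)B(O)OC2` carries the shared core with a 1-methyl-1H-pyrrol-2-yl group on its carbonyl carbon. In a toxicity assay on WI-38 cells (Homo sapiens) for cytotoxicity, read by MTT assay, with a stated time of 48 h (a lower number here means a stronger inhibitor, a higher number a weaker inhibitor), compound 1 gives only a limit, > 100000 nM, not a number. Compound 2 `CCc1ccc(C(=O)/C=C/c2ccc3c(c2)B(O)OC3)cc1` gives 20600 nM in this assay. Compound 3 `O=C(/C=C/c1ccc2c(c1)B(O)OC2)c1ccc(O)c(O)c1` also reaches only a limit, > 100000 nM. For the measured compounds named here, compound 1 thus sits at the limit of > 100000 nM in this assay, at which 2 of the 3 values shown sit, so no measured step between single-change neighbours exists. Compound 4 `Nc1cccc(C(=O)/C=C/c2ccc3c(c2)B(O)OC3)c1` differs from compound 1 by 3-aminophenyl in place of 1-methyl-1H-pyrrol-2-yl on a carbonyl carbon. The step of an at least 1.6-fold lower number from compound 1 to compound 4 (0.22 log units; that floor lies within the scatter) is expected to be modest, a shift toward a somewhat stronger value, because compound 2 with a plain phenyl-type ring reaches 20600 nM. Compound 4 is estimated at 60000 nM, within a range from 15000 nM to 300000 nM.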

Compound 4, half-maximal inhibitory concentration: 25300 nM
Estimate against measurement, compound 4: 2.4-fold (0.38 log units) above; low and high end bracket the measured number.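

Putting 3-aminophenyl in place of 1-methyl-1H-pyrrol-2-yl on the carbonyl carbon gives an at least 3.9-fold lower number from compound 1 to compound 4 (0.59 log units; beyond the scatter) in this assay. For the compounds shown here, this is the first comparison here between compounds that differ in one place, and it shows that changing the group at this position alone can shift the result. The step gives only a minimum size, since the value for compound 1 is a limit: the limit of > 100000 nM in this assay, at which 2 of the 4 values shown sit.

Whether the six-membered ring or its amine accounts for the change remains open. An unsubstituted phenyl group on the same carbonyl carbon would separate the two.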